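A few compounds are considered here, and "the series" means these few. Any claim that something is new, unique, unknown or untested is made for them only; others in the source may bear on it.

The three measured compounds are compound 1 `CC(C)(Oc1ccccc1)C1OCC(C/C=C\CCC(=O)O)C(c2cccnc2)O1` with 75.9 nM, compound 2 `COc1ccccc1OC(C)(C)C1OCC(C/C=C\CCC(=O)O)C(c2cccnc2)O1` with 224 nM, and compound 3 `CC(C)(Oc1ccccc1[N+](=O)[O-])C1OCC(C/C=C\CCC(=O)O)C(c2cccnc2)O1` with 11.2 nM, all in a functional assay for inhibition, with Homo sapiens as the target; a higher number here means weaker binding, a lower number tighter binding.

The change from compound 1 to compound 2 is methoxy in place of hydrogen on an aromatic carbon, and in this assay it gave a 3.0-fold higher number from compound 1 to compound 2 (0.47 log units; beyond the scatter). Compound 3 differs from compound 1 by nitro in place of hydrogen on an aromatic carbon, which gave a 6.8-fold lower number from compound 1 to compound 3 (0.83 log units; beyond the scatter); the pair compound 2 to compound 3 gave a 20-fold lower number from compound 2 to compound 3 (1.30 log units; beyond the scatter). Compound 4 `COc1ccc(OC(C)(C)C2OCC(C/C=C\CCC(=O)O)C(c3cccnc3)O2)c([N+](=O)[O-])c1` is not yet measured; it differs from compound 3 by methoxy in place of hydrogen on an aromatic carbon. This is the same kind of change as from compound 1 to compound 2, but its place differs: in compound 2 the methoxy sits ortho to a large group, whereas in compound 4 it sits meta to a nitro group and para to a large group.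

Because compound 2 showed a 3.0-fold higher number from compound 1 to compound 2 (0.47 log units; beyond the scatter), a modest weakening is expected again in this assay, as a 2.2-fold higher number from compound 3 to compound 4 (0.35 log units; beyond the scatter). The estimate for compound 4 in this assay is 25 nM, expected to lie between 9 nM and 70 nM.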

Compound 4, dissociation constant: 6.17 nM
For compound 4 the middle estimate is 4.1-fold (0.61 log units) above the measured one; measured number below the stated range.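

In this assay, methoxy in place of hydrogen on an aromatic carbon gave a 1.8-fold lower number from compound 3 to compound 4 (0.26 log units; within the scatter), and this step does not match the earlier one: the same change on two cores in this assay, a 3.0-fold higher number (0.47 log units; beyond the scatter) from compound 1 to compound 2 and a 1.8-fold lower number (0.26 log units; within the scatter) from compound 3 to compound 4, 5.4-fold (0.73 log units) apart, beyond the scatter of two such steps. With 4-methoxy-2-nitrophenyl in place of phenyl the result was a 12-fold lower number from compound 1 to compound 4 (1.09 log units; beyond the scatter), and with the same group in place of 2-methoxyphenyl it was a 36-fold lower number from compound 2 to compound 4 (1.56 log units; beyond the scatter). The higher number seen on the core of compound 1 therefore did not carry over to the core of compound 3, which shows that the change cannot be treated as one fixed step in this series, but the two pairs differ both in the nitro group and in where the methoxy sits, so they do not show which of the two matters.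

Still open, as far as these compounds go, is how a methoxy para to a large group would read on the core of compound 1, which would separate place from the nitro group. Also open, from the compounds shown here alone, is how an amine in place of the nitro group would read with the methoxy kept.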